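The source may hold more compounds than are shown below. What is called first, only, known or untested is meant among the compounds shown, and "the series" means these compounds.

Measured so far in a functional assay on K562 cells (Homo sapiens) for antiproliferative activity, read by MTT assay, with a stated time of 24 h; on this read-out lower numbers stand for stronger inhibition and higher numbers for weaker inhibition:
- compound 1 `COc1ccc(C(=O)/C=C/c2ccc(-c3ccccc3)cc2)c2c1C=CC(C)(C)O2` (> 10000 nM)
- compound 2 `COc1ccc(C(=O)/C=C/c2ccc(-n3ccnc3)cc2)c2c1C=CC(C)(C)O2` (> 10000 nM)

Compound 1 gives > 10000 nM as a limit of the assay and not as a number. Compound 2 likewise gives > 10000 nM as a limit and not as a number, so its position in this assay is known only as that limit.

Next in the series is compound 3 `COc1ccc(C(=O)/C=C/c2ccc(C(F)(F)F)cc2)c2c1C=CC(C)(C)O2`. The change is trifluoromethyl in place of 1H-imidazol-1-yl on an aromatic carbon and sits para to a large group, with trifluoromethyl in place of 1H-imidazol-1-yl on an aromatic carbon.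

Within the data shown here, the only measured step bearing on this is a step that the two limits leave unreadable from compound 1 to compound 2 and it offers no size to carry over. The evidence amounts to the limit of > 10000 nM in this assay, at which 2 of the 2 values shown sit, for compound 1 and compound 2 alike. No step beyond the scatter is therefore expected in this assay and another limit is the likeliest result. Any readable departure would be expected toward stronger inhibition. The expected change is a number no higher from compound 2 to compound 3 (the limit leaves the size open) as an estimate only. Compound 3 is estimated at 10000 nM (expected range 3000 nM to 30000 nM).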

Compound 3, half-maximal inhibitory concentration: > 10000 nM
Compound 3: no number, only a limit; the forecaster's own chance of this, stated with the estimate: 70%; the middle value lies on the limit itself.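

Compound 3 gives > 10000 nM as a limit of the assay and not as a number. No new step can be read among compound 1, compound 2 and compound 3. The compounds shown leave open how far each lies from that limit, and whether any group in this place gives a readable number in this assay at all.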